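Pyridin-4-yl Analogue of Compound 3: Expectation Before Measurement

This account rests on a few compounds, and the source may have more. Where it says the series, first, only, none or still open, it means among the compounds named here.

Three compounds of this series have numbers in a functional assay on the whole organism (plasma, strain Wistar) with Rattus norvegicus as the target, with a stated time of 15 days, at a dose of 30 mg/kg by the oral route; on this read-out higher numbers stand for a stronger effect at the one dose given and lower numbers for a weaker effect. Compound 1 `O=C1NC(=O)/C(=C/c2ccc(OCCSc3nnc(-c4ccccc4)o3)cc2)S1` gives 16.1%. Compound 2 `O=C1NC(=O)/C(=C/c2ccc(OCCSc3nnc(Cc4ccccc4)o3)cc2)S1` gives 19.1%. Compound 3 `O=C1NC(=O)/C(=C/c2ccc(OCCSc3nnc(-c4cccnc4)o3)cc2)S1` gives 39.3% and stands highest of the three, with its steps to the other two both beyond the scatter.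

The steps among them: a number 3 percentage points higher from compound 1 to compound 2 (within the scatter); a number 23.2 percentage points higher from compound 1 to compound 3 (beyond the scatter); a number 20.2 percentage points higher from compound 2 to compound 3 (beyond the scatter).

Compound 4 `O=C1NC(=O)/C(=C/c2ccc(OCCSc3nnc(-c4ccncc4)o3)cc2)S1` is the next compound to be measured. It differs from compound 3 in one place: pyridin-4-yl in place of pyridin-3-yl on an aromatic carbon. The two compounds hold the same atoms, joined differently.

Among the measured compounds shown here, two measured steps bear on this, both ending at compound 3: the change from phenyl to pyridin-3-yl and from benzyl to pyridin-3-yl, each a modest rise beyond the scatter. For the measured compounds named here, neither step moves the ring nitrogen within the six-membered ring, so no measured step tells directly what shifting it from pyridin-3-yl to pyridin-4-yl does. The pyridin-3-yl ring is the only one that lifted the read-out; whether a pyridin-4-yl ring holds that gain is open.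

The expectation for compound 4 is a number close to that of compound 3, with a step of a number 6.3 percentage points lower from compound 3 to compound 4 (within the scatter) that may fall within the scatter. Compound 4 is estimated at 33%, within a range from 16% to 50%.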

Compound 4, a percentage reported as activity, at one dose (the size of the read-out at that dose, not a potency): 40%
Compound 4: the middle estimate sits 7 percentage points below what was measured; low and high end bracket the measured number.
By their numbers in this assay, from the lowest: compounds 1 and 2 (each within the scatter of the next); then compounds 3 and 4 (each within the scatter of the next).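

In this assay, among the compounds shown here, the shift from pyridin-3-yl to pyridin-4-yl on the five-membered aromatic ring gives a number 0.7 percentage points higher from compound 3 to compound 4 (within the scatter), so at this position the two pyridine rings cannot be told apart, a point the earlier compounds could not settle. The gain over the rings without a ring nitrogen is therefore not confined to pyridin-3-yl: the change from benzyl gives a number 20.9 percentage points higher from compound 2 to compound 4 (beyond the scatter), and the change from phenyl gives a number 23.9 percentage points higher from compound 1 to compound 4 (beyond the scatter). Among these four compounds, both pyridine rings stand clear of phenyl and benzyl, but no measurement shown explains this or separates the effect of the ring nitrogen's placement from that of its presence.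

Going by these compounds, whether a pyridin-2-yl ring, or a phenyl ring carrying an amine or a carboxylic acid, would keep the read-out of the two pyridine rings remains open. Also open, on these data alone, are how compound 3 and compound 4 would behave at other doses, since this read-out gives the size of the effect at one dose and not a potency, and whether a longer chain in the shared core would keep that effect.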